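From propyl to cyclopropyl on a shared core

A few compounds are considered here, and "the series" means these few. Any claim that something is new, unique, unknown or untested is made for them only; others in the source may bear on it.

- compound 1 `CCCCc1cn2ccccc2c1S(=O)(=O)c1ccc(OCCCN(CCCC)CCCC)cc1`: 284 nM
- compound 2 `CCCCN(CCCC)CCCOc1ccc(S(=O)(=O)c2c(CCC)cn3ccccc23)cc1`: 54.3 nM

In a functional assay (aorta) with Rattus norvegicus as the target (on this read-out higher numbers stand for weaker inhibition and lower numbers for stronger inhibition), compound 2 holds the lower of the two numbers, which means the stronger inhibition. Compound 3 `CCCCN(CCCC)CCCOc1ccc(S(=O)(=O)c2c(C3CC3)cn3ccccc23)cc1` differs from it by cyclopropyl in place of propyl on an aromatic carbon, with cyclopropyl in place of propyl on an aromatic carbon. Among the compounds with values here, only one measured step touches this chain: a 5.2-fold lower number from compound 1 to compound 2 (0.72 log units; beyond the scatter), with hydrogen in place of methyl on a saturated chain carbon. Within the data shown here, that step shows the chain matters, but no measured compound has a ring there, so no direction can be predicted. A step of similar size either way is possible, though little net change is expected. The estimated change is a 1.1-fold higher number from compound 2 to compound 3 (0.04 log units; within the scatter) in this assay terms. For compound 3 the expected value is 60 nM, with an estimated range of 15 nM to 240 nM here.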

Compound 3, half-maximal inhibitory concentration: 10.9 nM
Beside the measured number, compound 3's estimate is 5.5-fold (0.74 log units) above it; measured number below the stated range.
By their numbers in this assay, from the lowest: compound 3; then compound 2; then compound 1.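

In this assay, closing propyl into cyclopropyl keeps the same 3 carbons yet gives a 5.0-fold lower number from compound 2 to compound 3 (0.70 log units; beyond the scatter), so at this position a ring counts for more than the number of carbons alone. Set against the butyl of compound 1, the same ring gives a 26-fold lower number from compound 1 to compound 3 (1.42 log units; beyond the scatter), a larger change than the one seen on trimming the chain. No measurement here explains why the ring does better.

The compounds shown leave open whether isopropyl or cyclobutyl at this position would lower the number further or lose the gain.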